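A few compounds are considered here, and "the series" means these few. Any claim that something is new, unique, unknown or untested is made for them only; others in the source may bear on it.

Measured so far:
compound 1 `O=c1[nH]c2ccccc2oc1=O`: 42000 nM
compound 2 `O=c1[nH]c2ccc(O)cc2oc1=O`: 170000 nM

In a functional assay with Rattus norvegicus as the target (on this read-out lower numbers stand for stronger inhibition and higher numbers for weaker inhibition), compound 1 holds the lower of the two numbers; the only other point lies one step away, a 4.0-fold higher number from compound 1 to compound 2 (0.61 log units; beyond the scatter). Compound 3 `O=c1[nH]c2cc(C(F)(F)F)ccc2oc1=O` differs from compound 1 by trifluoromethyl in place of hydrogen on an aromatic carbon. Among the compounds with values here, the single measured step concerns a different entering group, hydroxy, so nothing measured bears directly on trifluoromethyl, and its modest size gives no ground to expect a large shift. The step from compound 1 is therefore expected to stay within the scatter in this assay, a 1.1-fold lower number from compound 1 to compound 3 (0.02 log units; within the scatter). Compound 3 is estimated at 40000 nM, with a range from 14000 nM to 120000 nM.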

Compound 3, half-maximal inhibitory concentration: 100000 nM
Beside the measured number, compound 3's estimate is 2.5-fold (0.40 log units) below it; low and high end bracket the measured number.
By their numbers in this assay, from the lowest: compound 1; then compounds 3 and 2 (each within the scatter of the next).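

In this assay, trifluoromethyl in place of hydrogen on an aromatic carbon gives a 2.4-fold higher number from compound 1 to compound 3 (0.38 log units; beyond the scatter), so a substituent at this place, meta to a fused ring and para to a fused ring, raises the number. With a 4.0-fold higher number from compound 1 to compound 2 (0.61 log units; beyond the scatter) also on record, both entering groups shown raise the number, and the unsubstituted compound 1 stays lowest. Nothing at hand accounts for the rise.

On these data alone, whether fluorine, methyl or an amine at this place would hold the number of compound 1 remains open. Also open, as far as these compounds go, is whether the rise follows trifluoromethyl itself or the place it occupies.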